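Fluoro for Methoxy on an Unsaturated Lactone Side Chain

The compounds below may be only part of what the source reports. "The series", "measured", "known", "first", "only" and "open" are said of these compounds alone.

compound 1 `COc1ccc(/C=C/[C@H]2CC=CC(=O)O2)cc1` — > 100000 nM
compound 2 `O=C1C=CC[C@H](/C=C/C2CCCCC2)O1` — 31000 nM
compound 3 `O=C1CCC[C@@H]([C@H]2C[C@@H]2c2ccccc2)O1` — > 100000 nM

In a functional assay on A549 cells (Homo sapiens) for antiproliferative activity, read by luminescence and CellTiter-Glo, with a stated time of 48 h (a lower number here means a stronger inhibitor, a higher number a weaker inhibitor), compound 1 gives > 100000 nM, which is a limit of the assay and not a number. Compound 2, the only one of the three with a number rather than a limit, gives 31000 nM. Compound 3 also gives only a limit, > 100000 nM. On the values shown, compound 1 therefore stands at the limit of > 100000 nM in this assay, at which 2 of the 3 values shown sit, and no ordering among the three can be drawn beyond that.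

Compound 4 `O=C1C=CC[C@H](/C=C/c2ccc(F)cc2)O1` is the next candidate, and it differs from compound 1 by fluoro in place of methoxy on an aromatic carbon. Among the measured compounds shown here, no measured pair of compounds shows this same change, so the size of the step cannot be read from the data; both compound 1 and compound 3 sit at the limit, and only compound 2 lies inside the measurable range. Compound 4 is expected to remain weak, with an estimated step of an at least 1.2-fold lower number from compound 1 to compound 4 (0.09 log units; that floor lies within the scatter) that may well leave it at the limit again. For compound 4 the estimate is 80000 nM, with a range from 20000 nM to 300000 nM.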

Compound 4, half-maximal inhibitory concentration: 10200 nM
Compound 4: middle estimate off by 7.8-fold (0.89 log units), on the high side; measured number below the stated range.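

In this assay, fluoro in place of methoxy on an aromatic carbon of the six-membered ring gives an at least 9.8-fold lower number from compound 1 to compound 4 (0.99 log units; beyond the scatter), the only single change shown that can be followed at this position, and it brings the compound inside the measurable range. Compound 1 gives > 100000 nM, which is a limit and not a number. The step can therefore be read only as a lower bound, and its true size stays unknown: the limit of > 100000 nM in this assay, at which 2 of the 4 values shown sit.

The compounds shown leave open whether the gain goes with fluoro itself or with the departure of methoxy, as a bare hydrogen, a chloro or a hydroxyl at this place is not among them. They also do not tell whether the same change would carry over to another core, such as that of compound 3.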